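The compounds below may be only part of what the source reports. "The series", "measured", "known", "first", "only" and "open" are said of these compounds alone.

Compounds measured in a functional assay on Jurkat cells for inhibition of nuclear factor NF-kappa-B complex (Homo sapiens); a lower number here means a stronger inhibitor, a higher number a weaker inhibitor:
compound 1, `CCOC(=O)c1cnc(CC)nc1NN1C(=O)C=C(C)C1=O`, 10000 nM
compound 2, `CCOC(=O)c1cnc(-c2cccs2)nc1NN1C(=O)C=C(C)C1=O`, 20 nM
compound 3, `CCOC(=O)c1cnc(-c2ccsc2)nc1NN1C(=O)C=C(C)C1=O`, 100 nM

Compound 3 stands second of the three in this assay : compound 2 gives the lower number, by a 5.0-fold higher number from compound 2 to compound 3 (0.70 log units; beyond the scatter), and compound 1 the higher one, by a 100-fold lower number from compound 1 to compound 3 (2.00 log units; beyond the scatter). The steps from the ethyl compound to the two thiophene compounds were both large, a 500-fold lower number from compound 1 to compound 2 (2.70 log units; beyond the scatter) and a 100-fold lower number from compound 1 to compound 3 (2.00 log units; beyond the scatter).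

Compound 4, `CCOC(=O)c1cnc(CC2=CCCCC2)nc1NN1C(=O)C=C(C)C1=O`, is not yet measured. It differs from compound 3 by (cyclohex-1-en-1-yl)methyl in place of thiophen-3-yl on an aromatic carbon. Among the compounds with values here, no measured step covers this exact change. The closest guide is compound 1, whose ethyl group, like the incoming group, has no aromatic ring at this position and is joined through a saturated carbon; that compound gave 10000 nM. The two large steps from compound 1 show that an aromatic five-membered ring at this position is what carried the gain, and compound 4 loses that ring. A step back toward the number of compound 1 is therefore expected, although the entering group is larger than ethyl and the data do not tell how a non-aromatic ring of this size behaves here. Compound 4 is expected at 2000 nM, range 300 nM to 10000 nM, which means an expected step of a 20-fold higher number from compound 3 to compound 4 (1.30 log units; beyond the scatter) in this assay.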

Compound 4, half-maximal inhibitory concentration: 2000 nM
Estimate against measurement, compound 4: no gap at the digits printed, and the stated range covers the measured number.
By their numbers in this assay, from the lowest: compound 2; then compound 3; then compound 4; then compound 1.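

At this position, on the aromatic carbon between two ring nitrogen atoms, a carbocyclic ring does not stand in for a thiophene in this assay: (cyclohex-1-en-1-yl)methyl gives a 20-fold higher number from compound 3 to compound 4 (1.30 log units; beyond the scatter) and a 100-fold higher number from compound 2 to compound 4 (2.00 log units; beyond the scatter), so these two thiophene groups are well ahead of this larger non-aromatic group. The same group does not fall back fully to the ethyl level either, with a 5.0-fold lower number from compound 1 to compound 4 (0.70 log units; beyond the scatter), which shows that groups joined through a saturated carbon are not all equal here, something compound 1 alone could not show. No measurement on hand explains either difference.

The change from compound 3 to compound 4 swaps the aromatic ring for a non-aromatic one and also adds a saturated linking carbon, so the two contributions stay unseparated; a benzyl group and a directly attached cyclohexyl group would pull them apart. Where a phenyl group or a cyclic amine such as morpholine would fall in this order also remains open.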